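Shifting the Aryl Ether Substituent Toward a Methoxy Group

This account rests on a few compounds, and the source may have more. Where it says the series, first, only, none or still open, it means among the compounds named here.

Of the compounds shown here, three sharing one macrocyclic core have been measured so far. Compound 1, `CC[C@@H]1/C=C(\C)C[C@H](C)C[C@H](OC)[C@H]2O[C@@](O)(C(=O)C(=O)N3CCCC[C@H]3C(=O)O[C@H](/C(C)=C/[C@@H]3CC[C@@H](O)[C@H](Oc4ccc(O)cc4)C3)[C@H](C)[C@@H](O)CC1=O)[C@H](C)C[C@@H]2OC`, gives 0.9 nM in a functional assay on cells for inhibition, with Murine T-cell line (Mus musculus) as the target; on this read-out higher numbers stand for weaker inhibition and lower numbers for stronger inhibition. Compound 2, `CC[C@@H]1/C=C(\C)C[C@H](C)C[C@H](OC)[C@H]2O[C@@](O)(C(=O)C(=O)N3CCCC[C@H]3C(=O)O[C@H](/C(C)=C/[C@@H]3CC[C@@H](Oc4ccc(O)cc4)[C@H](OC)C3)[C@H](C)[C@@H](O)CC1=O)[C@H](C)C[C@@H]2OC`, gives 0.8 nM in this assay, the lowest of the three numbers, though its difference from compound 1 lies within the usual scatter, so the two are not distinguished. Compound 3, `CC[C@@H]1/C=C(\C)C[C@H](C)C[C@H](OC)[C@H]2O[C@@](O)(C(=O)C(=O)N3CCCC[C@H]3C(=O)O[C@H](/C(C)=C/[C@@H]3CC[C@@H](Oc4cc(C(F)(F)F)cc(C(F)(F)F)c4)[C@H](OC)C3)[C@H](C)[C@@H](O)CC1=O)[C@H](C)C[C@@H]2OC`, gives 607 nM in this assay, far beyond the scatter from compound 2.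

The next compound, compound 4, `CC[C@@H]1/C=C(\C)C[C@H](C)C[C@H](OC)[C@H]2O[C@@](O)(C(=O)C(=O)N3CCCC[C@H]3C(=O)O[C@H](/C(C)=C/[C@@H]3CC[C@@H](Oc4cccc(OC)c4)[C@H](OC)C3)[C@H](C)[C@@H](O)CC1=O)[C@H](C)C[C@@H]2OC`, has not been measured. Its structure differs from compound 2 in one place: 3-methoxyphenyl in place of 4-hydroxyphenyl on an oxygen on a saturated carbon.

No change of this exact kind has been measured here, so its size can only be estimated. Compound 3 shows that a heavily substituted aryl ether at this position can cost a great deal, because 607 nM stands far above compound 2. The present change is more modest, and compound 4 is therefore expected to lose some inhibition but to remain well short of compound 3. The step of a 10-fold higher number from compound 2 to compound 4 (1.00 log units; beyond the scatter) is the expected outcome. Compound 4 is estimated at 8 nM, with a plausible range from 1 nM to 60 nM.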

Compound 4, half-maximal inhibitory concentration: 3.4 nM
For compound 4 the middle estimate is 2.4-fold (0.37 log units) above the measured one; low and high end bracket the measured number.
By their numbers in this assay, from the lowest: compounds 2 and 1 (each within the scatter of the next); then compound 4; then compound 3.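

The change to 3-methoxyphenyl in place of 4-hydroxyphenyl on an oxygen on a saturated carbon gives, in this assay, a 4.3-fold higher number from compound 2 to compound 4 (0.63 log units; beyond the scatter), a step that is beyond the scatter but modest. The hydrogen-bond donor of the 4-hydroxyphenyl group can therefore be lost at this position with strong inhibition retained, while compound 4 differs in this same place from compound 3, which gives 607 nM, so the high number of compound 3 does not extend to every substituted aryl ether here. No measured evidence is available to explain the size of this step.

The step exchanges the hydroxy group for a methoxy group and moves the substituent around the ring at the same time, so the compounds shown do not separate the contribution of each, and a comparison with 4-methoxyphenyl would be needed to do so. Also open, going by these compounds, is how a phenyl ring bearing an amine, a carboxylic acid or a longer alkoxy chain would read in this assay.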